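A few compounds are considered here, and "the series" means these few. Any claim that something is new, unique, unknown or untested is made for them only; others in the source may bear on it.

The three compounds measured in an ADME assay on microsomes from liver (Homo sapiens) for metabolic stability, tested at 2.5 uM (a lower number here means slower removal, a higher number faster removal of the compound), are:

compound 1, `COc1ccc(-c2c(S(=O)(=O)c3cccc(C#N)c3)cnc3cc(F)ccc23)cc1`, which gives 0.92 mL/min
compound 2, `N#Cc1cccc(S(=O)(=O)c2cnc3cc(F)ccc3c2-c2cccc(Cl)c2)c1`, which gives 0.99 mL/min
compound 3, `COc1ccc(S(=O)(=O)c2cnc3cc(F)ccc3c2-c2cccc(Cl)c2)cc1Cl`, which gives 1.19 mL/min

Compound 2 holds the second highest of the three numbers, and both of its neighbours sit within the scatter of it: the nearest is given by a 1.1-fold higher number from compound 1 to compound 2 (0.03 log units; within the scatter), the furthest by a 1.2-fold higher number from compound 2 to compound 3 (0.08 log units; within the scatter). The three measured values therefore cannot be told apart by this assay.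

Compound 4, `N#Cc1cccc(S(=O)(=O)c2cnc3cc(F)ccc3c2-c2ccccc2F)c1`, has not yet been measured. It differs from compound 2 in one place: 2-fluorophenyl in place of 3-chlorophenyl on an aromatic carbon.

The measured step that bears on this change is a 1.1-fold higher number from compound 1 to compound 2 (0.03 log units; within the scatter), since it likewise exchanges the aryl group on the same aromatic carbon of the shared core, and it stayed within the scatter. The step of a 1.2-fold higher number from compound 2 to compound 3 (0.08 log units; within the scatter) alters the group on the sulfonyl sulfur instead and was also within the scatter. On this basis the expected step for compound 4 is a 1.0-fold higher number from compound 2 to compound 4 (0.00 log units; within the scatter), that is, nothing beyond the scatter in either direction. Compound 4 is accordingly estimated to give 1 mL/min in this assay, with a range from 0.6 mL/min to 1.7 mL/min.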

Compound 4, intrinsic clearance in a liver preparation (reported as CLH), per the amount of preparation that the assay uses: 1.39 mL/min
Estimate against measurement, compound 4: 1.4-fold (0.14 log units) below; measured number inside the range.
By their numbers in this assay, from the lowest: compounds 1, 2, 3 and 4 (each within the scatter of the next).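

In this assay, the aromatic carbon opposite the ring nitrogen now carries a third kind of substituted phenyl: 2-fluorophenyl in place of 3-chlorophenyl gives a 1.4-fold higher number from compound 2 to compound 4 (0.15 log units; within the scatter) and 2-fluorophenyl in place of 4-methoxyphenyl gives a 1.5-fold higher number from compound 1 to compound 4 (0.18 log units; within the scatter) as the wider of the two new steps. With the 3-cyanophenyl on the sulfonyl sulfur held constant, 4-methoxyphenyl, 3-chlorophenyl and 2-fluorophenyl thus all stay within the scatter of one another on this carbon, so no order among these three groups can be read from the numbers. Nothing in the data shown speaks to what lies behind these numbers.

The compounds shown leave open whether a group other than a substituted phenyl on this carbon, such as an amine or a carboxylic acid, would give a step beyond the scatter in this assay at all. They also leave open whether 2-fluorophenyl would stay within the scatter of 3-chlorophenyl with the 3-chloro-4-methoxyphenyl of compound 3 on the sulfonyl sulfur.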